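Swapping the Sulfonamide Aryl Group: Compound 2 to Compound 4

A few compounds are considered here, and "the series" means these few. Any claim that something is new, unique, unknown or untested is made for them only; others in the source may bear on it.

Of the compounds shown here, three sharing one core have been measured. Compound 1 `CCN(CC)Cc1ccc(S(=O)(=O)NCc2ccc(CNC(=O)c3ccc(F)cc3)cc2)cc1`, compound 2 `O=C(NCc1ccc(CNS(=O)(=O)c2cccc(Cl)c2)cc1)c1ccc(F)cc1` and compound 3 `O=C(NCc1ccc(CNS(=O)(=O)c2ccc(CN3CCCC3)cc2)cc1)c1ccc(F)cc1` differ only in the group on the sulfonyl sulfur and, between compound 1 and compound 3, at a saturated chain carbon bound to an aromatic carbon. In an assay on MDA-MB-231 cells for binding affinity to C-X-C chemokine receptor type 4 (Homo sapiens), read by fluorescence and microscopy, with stated times of 10 min and 30 min (a higher number here means that more compound is needed for the effect, a lower number that less compound is needed), compound 1 gives 1 nM, compound 2 gives 1 nM and compound 3 gives 1 nM. For the measured compounds named here, the one step that joins two of them, no change at the digits printed from compound 1 to compound 3 (within the scatter), lies within the scatter, and compound 2 stands level with both.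

Compound 4 `O=C(NCc1ccc(CNS(=O)(=O)c2ccccc2F)cc1)c1ccc(F)cc1` has not yet been measured. It differs from compound 2 by one change: 2-fluorophenyl in place of 3-chlorophenyl on a sulfonyl sulfur. Going by the values given here, no measured step touches that place directly, yet the three measured compounds carry quite different groups there and still give the same value, so no step beyond the scatter is expected in this assay, and a 1.2-fold higher number from compound 2 to compound 4 (0.08 log units; within the scatter) is the expected size. Compound 4 is therefore estimated at 1.2 nM, with a likely range from 0.5 nM to 4 nM.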

Compound 4, effective concentration (reported as EC, without a stated level of effect): 10 nM
Compound 4: middle estimate off by 8.3-fold (0.92 log units), on the low side, and the stated range ends below it.
By their numbers in this assay, from the lowest: compounds 1, 2 and 3 (each within the scatter of the next); then compound 4.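

For the compounds shown here, this step shows that the group on the sulfonyl sulfur can matter in this assay, which the level values of the earlier compounds gave no sign of: there is a 10-fold higher number from compound 2 to compound 4 (1.00 log units; beyond the scatter), a step beyond the scatter. The change looks small on paper, since 3-chlorophenyl and 2-fluorophenyl are both six-membered aromatic rings of carbon with the same count of heavy atoms, no hydrogen-bond donors or acceptors and no net charge. Both the halogen and its place on the ring differ, so this single step cannot separate the two, and nothing in the data shown explains it.

A 2-chlorophenyl or 3-fluorophenyl group on the sulfonyl sulfur would tell the halogen's effect from that of its place. Also open, going by these compounds, is how a 2-fluorophenyl ring carrying an added carboxylic acid would behave here.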